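Swapping the sulfonyl ring: inhibition near the ceiling

This account rests on a few compounds, and the source may have more. Where it says the series, first, only, none or still open, it means among the compounds named here.

Compound 1 `CNCc1cn(S(=O)(=O)c2cccs2)c(-c2cccnc2F)c1F` and compound 2 `CNCc1cn(S(=O)(=O)c2cncc(F)c2)c(-c2cccnc2F)c1F` share one core and differ only at the sulfonyl sulfur. In a functional assay on the whole organism (strain Jcl:Sprague-Dawley) for inhibition, with Rattus norvegicus as the target, with stated times of 3 min and 3 h, at a dose of 1 mg/kg by the intravenous route (a lower number here means less inhibition, a higher number more inhibition at the dose given (going by the name of the read-out)), compound 1 gives 98%, and compound 2 gives 99%; the step of a number 1 percentage points higher from compound 1 to compound 2 (within the scatter) shows the two numbers level, within the scatter of each other. Compound 3 `CNCc1cn(S(=O)(=O)c2cccnc2C)c(-c2cccnc2F)c1F` changes that same sulfonyl ring again: 2-methylpyridin-3-yl in place of 5-fluoropyridin-3-yl on a sulfonyl sulfur. Within the data shown here, the one step that bears on this place left the read-out unchanged, so no step beyond the scatter is expected, a number 4 percentage points lower from compound 2 to compound 3 (within the scatter). Compound 3 is therefore estimated at 95%, in the range 82% to 100%.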

Compound 3, a percentage reported as inhibition, in the whole organism at one dose (the size of the read-out at that dose, not a potency): 92%
Compound 3: the middle estimate sits 3 percentage points above what was measured, within the range that was stated.
By their numbers in this assay, from the lowest: compounds 3, 1 and 2 (each within the scatter of the next).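

In this assay the 2-methylpyridin-3-yl ring gives a number 7 percentage points lower from compound 2 to compound 3 (within the scatter) and a number 6 percentage points lower from compound 1 to compound 3 (within the scatter) so the three compounds stay level. A pyridine ring carrying a methyl group and no fluorine therefore fits on the sulfonyl sulfur as well as the thiophen-2-yl and 5-fluoropyridin-3-yl rings do. No measured evidence explains this result.

All three compounds lie close to the top of the scale at this one dose, so this read-out barely separates them. As far as these compounds go, what a sulfonyl ring bearing an amine or a carboxylic acid would give remains open.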